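Aryl ether variation on the shared core

This account rests on a few compounds, and the source may have more. Where it says the series, first, only, none or still open, it means among the compounds named here.

The series keeps one core and varies the aryl group on the ether oxygen. Compound 1 `Cc1cccc(Nc2ncc(Br)c(Oc3cccc(F)c3)n2)c1` carries a 3-fluorophenyl there; in a functional assay on MDA-MB-468 cells (Homo sapiens) for antiproliferative activity, read by MTT assay, with a stated time of 24 h (a lower number here means a stronger inhibitor, a higher number a weaker inhibitor), compound 1 gives 29200 nM. Compound 2 `Cc1cccc(Nc2ncc(Br)c(Oc3ccc(Br)cc3)n2)c1` carries a 4-bromophenyl; in this assay compound 2 gives 31300 nM. Within the data shown here, the only measured step is a 1.1-fold higher number from compound 1 to compound 2 (0.03 log units; within the scatter). Of the two numbers, compound 2 shows the larger one, but its gap to compound 1, the nearest compound, is within the scatter, so the two are not separated by this assay.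

Compound 3 `Cc1cccc(Nc2ncc(Br)c(Oc3ccc(OCc4ccccc4)cc3)n2)c1` differs from compound 2 by benzyloxy in place of bromo on an aromatic carbon. Among the measured compounds shown here, no measured step swaps bromo for benzyloxy, so the change itself is untested. For the measured compounds named here, the single step that bears on it, a 1.1-fold higher number from compound 1 to compound 2 (0.03 log units; within the scatter), altered the same aryl ether and stayed within the scatter. Going by the values given here, on that basis no step beyond the scatter is expected in this assay from compound 2 to compound 3, though the entering group has no counterpart among the measured compounds and the uncertainty is wide. The expected step is a 1.1-fold lower number from compound 2 to compound 3 (0.05 log units; within the scatter). Compound 3 is therefore estimated at 28000 nM, within a range of 8000 nM to 90000 nM.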

Compound 3, half-maximal inhibitory concentration: > 50000 nM
Compound 3 was reported as a limit; the forecaster's own chance of this, stated with the estimate: 10%; middle value at least 1.7-fold (0.25 log units) away from the limit.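

In this assay compound 3 gives > 50000 nM as a limit of the assay and not a number, so the reading marks a boundary only: the limit of > 50000 nM in this assay, at which 1 of the 3 values shown sits.

The step is an at least 1.5-fold higher number from compound 2 to compound 3 (0.20 log units; that floor lies within the scatter) and, taken at that floor, does not separate the two compounds, although the true gap may be wider. Among these compounds, what this adds to the earlier pair is a first look at a much larger change on the aryl ether: benzyloxy brings a second six-membered aromatic ring in place of bromo, and compound 3 shows no stronger reading than compound 2.

The compounds shown leave open how far compound 3 actually lies from compound 2, and whether the drop, if real, follows from the added ring or from the ether oxygen. A methoxy in the same place would keep the oxygen without the ring, while an amine or a carboxylic acid there would show whether any replacement for bromo at this position can bring the number down.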